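Swapping a piperidinyloxyethyl tail for a short branched amine

This account rests on a few compounds, and the source may have more. Where it says the series, first, only, none or still open, it means among the compounds named here.

Compound 1 `c1cc([C@H]2CC[C@]3(CC2)OOC2(O3)C3CC4CC(C3)CC2C4)ccc1OCCOC1CCNCC1`: 50 ug/mL
Compound 2 `c1cc([C@H]2CC[C@]3(CC2)OOC2(O3)C3CC4CC(C3)CC2C4)ccc1OCCC1CCNCC1`: > 100 ug/mL
Compound 3 `N[C@H]1CC[C@@H](Oc2ccc([C@H]3CC[C@]4(CC3)OOC3(O4)C4CC5CC(C4)CC3C5)cc2)CC1`: 25 ug/mL

In a physicochemical assay for solubility, read by nephelometry, measured as kinetic solubility, with a stated time of 30 min (a higher number here means a more soluble compound, a lower number a less soluble compound), compound 1 gives 50 ug/mL, the higher of the two plain numbers, while compound 3 sits at 25 ug/mL; the gap is a 2.0-fold lower number from compound 1 to compound 3 (0.30 log units; within the scatter). For compound 2 this assay reports only a limit, > 100 ug/mL. Compound 4 `CC(C)(CN)Oc1ccc([C@H]2CC[C@]3(CC2)OOC2(O3)C3CC4CC(C3)CC2C4)cc1` is not yet measured. It differs from compound 1 by 1-(aminomethyl)-1-methylethyl in place of 2-((piperidin-4-yl)oxy)ethyl on an oxygen on an aromatic ring. Going by the values given here, two measured steps bear on it. Dropping the ether oxygen read an at least 2.0-fold higher number from compound 1 to compound 2 (0.30 log units; that floor lies within the scatter), and moving to a shorter primary-amine group read a 2.0-fold lower number from compound 1 to compound 3 (0.30 log units; within the scatter), both within the scatter. Compound 4 combines a lost ether oxygen with a primary amine, so for compound 4 the step is expected to be a 1.1-fold lower number from compound 1 to compound 4 (0.05 log units; within the scatter), nothing beyond the scatter. Compound 4 is therefore estimated near 45 ug/mL, between 18 ug/mL and 100 ug/mL.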

Compound 4, solubility: > 100 ug/mL
Compound 4: a limit, no number (the forecaster's own chance of this, stated with the estimate: 20%); at least 2.2-fold (0.34 log units) between middle value and limit.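

At this position, on an oxygen on an aromatic ring, 1-(aminomethyl)-1-methylethyl, which has no ring, shows an at least 2.0-fold higher number from compound 1 to compound 4 (0.30 log units; that floor lies within the scatter). The clearer contrast in this assay is with 4-aminocyclohexyl, the other group with a primary amine, and it reads an at least 4.0-fold higher number from compound 3 to compound 4 (0.60 log units; beyond the scatter). The steps between the two limits cannot be read, and the top of the readable range is now shared: the limit of > 100 ug/mL in this assay, at which 2 of the 4 values shown sit.

As far as these compounds go, how far compound 2 and compound 4 actually lie apart remains open. So does whether a longer chain ending in the same amine, or a carboxylic acid in its place, would give a similar reading.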